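Cyclopropyl for Isopropyl on the Amide of Compound 1

The source may hold more compounds than are shown below. What is called first, only, known or untested is meant among the compounds shown, and "the series" means these compounds.

Compound 1, with the structure `CC(C)NC(=O)/C=C1\CCc2ccc(F)cc21`, was tested in a functional assay on the whole organism with Rattus norvegicus as the target, at a dose of 20 mg/kg by the oral route (on this read-out higher numbers stand for more inhibition at the one dose given (going by the name of the read-out) and lower numbers for less inhibition), where compound 1 gives 45%. Two companions share its core. Compound 3, `CNC(=O)/C=C1\CCc2cc(Cl)ccc21`, gives 40% in this assay, a number within the scatter of the result for compound 1. Compound 2, `COc1ccc2c(c1)/C(=C/C(N)=O)CC2`, gives 1% in this assay, well beyond the scatter below compound 1. Compound 1 thus stands at the upper end of the three numbers, level with compound 3 and clearly above compound 2.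

Compound 4, `O=C(/C=C1\CCc2ccc(F)cc21)NC1CC1`, has not yet been measured. It differs from compound 1 in one place: cyclopropyl in place of isopropyl on an amide-type nitrogen. Among the measured compounds shown here, no pair of measured compounds shows what such an exchange does here, so the size of the step is open. Since the group that leaves and the group that enters share the same count of carbons and neither adds a donor or acceptor, a step no larger than the scatter is expected, in either direction. The expected step of a number 3 percentage points lower from compound 1 to compound 4 (within the scatter) is small. Compound 4 is estimated at 42%, with a range from 20% to 65%.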

Compound 4, a percentage reported as inhibition, in the whole organism at one dose (the size of the read-out at that dose, not a potency): 5%
Estimate against measurement, compound 4: 37 percentage points above, and the stated range ends above it.
By their numbers in this assay, from the lowest: compounds 2 and 4 (each within the scatter of the next); then compounds 3 and 1 (each within the scatter of the next).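

Cyclopropyl in place of isopropyl on an amide-type nitrogen brings a number 40 percentage points lower from compound 1 to compound 4 (beyond the scatter) in this assay. The earlier compounds shown here differ from each other in more than one place, so they could not show that this single position matters so much on this read-out. The two groups have the same count of carbons and neither carries a hydrogen-bond donor or acceptor, so those counts alone do not predict the outcome here, and nothing at hand bears on the reason for the step.

From the compounds shown here alone, it remains open whether the loss belongs to the three-membered ring specifically or extends to other rings on this nitrogen. A cyclobutyl or cyclopentyl group there, or a longer chain such as n-butyl, would help to separate these possibilities.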